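The source may report more compounds than this note shows. Statements on the series, on what has been measured and on what is new or still open speak of the compounds shown alone.

Compound 1 `O=C1Nc2ccccc2/C1=N/NC(=S)N1CCN(c2ccccc2)CC1` gives 24900 nM in a functional assay on MCF7 cells (Homo sapiens) for inhibition, read by MTT assay, with a stated time of 72 h; on this read-out higher numbers stand for weaker inhibition and lower numbers for stronger inhibition.
Compound 2 `O=C1Nc2cc(Br)ccc2/C1=N/NC(=S)N1CCN(c2ccccc2)CC1` gives 19700 nM in this assay.
Compound 3 `O=C1Nc2ccc(Cl)cc2/C1=N/NC(=S)N1CCN(c2ccc(Cl)cc2)CC1` gives 13100 nM in this assay.

For the measured compounds named here, these three compounds share the same core, and all three numbers lie within the usual scatter of one another, so no compound can be called stronger or weaker than another on this evidence. Compound 3 has the smallest number of the three, yet its gaps to compound 2 and compound 1 are both within the scatter.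

Going by the values given here, the only single-point step available, a 1.3-fold lower number from compound 1 to compound 2 (0.10 log units; within the scatter), places a halogen on the aromatic ring of the core and changes nothing beyond the scatter.

Compound 4 `O=C1Nc2ccc(Cl)cc2/C1=N/NC(=S)N1CCN(c2ccccc2[N+](=O)[O-])CC1` differs from compound 3 in one place: 2-nitrophenyl in place of 4-chlorophenyl on an amine nitrogen in a ring. Among the compounds with values here, this change sits on the ring attached to the amine nitrogen, a position no measured step touches; compound 2 and compound 3 differ there, but also on the core, so nothing clean can be read from them. Within the data shown here, with no step bearing on this change and the only step elsewhere being flat, the expectation for compound 4 in this assay is a 1.1-fold higher number from compound 3 to compound 4 (0.03 log units; within the scatter), that is, no step beyond the scatter. Compound 4 is therefore estimated at 14000 nM, with a range from 5000 nM to 40000 nM.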

Compound 4, half-maximal inhibitory concentration: 7490 nM
Compound 4: the middle estimate sits 1.9-fold (0.27 log units) above what was measured; low and high end bracket the measured number.
By their numbers in this assay, from the lowest: compounds 4, 3, 2 and 1 (each within the scatter of the next, the first and the last beyond it).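

In this assay, for the compounds shown here, the step to 2-nitrophenyl in place of 4-chlorophenyl on an amine nitrogen in a ring is a 1.7-fold lower number from compound 3 to compound 4 (0.24 log units; within the scatter), the first clean reading at this position, and it shows that this exchange cannot be told apart from the ordinary spread of repeated measurements. The exchange is not a small one on paper: the group grows from 7 to 9 heavy atoms and goes from 0 to 2 hydrogen-bond acceptors, yet the two compounds still cannot be separated in this read-out. No independent measurement is available to explain why the two compounds read alike.

Whether an amine or a carboxylic acid on this same aromatic ring would shift the number beyond the scatter remains an open question. Going by these compounds alone, it is also unknown whether the exchange would read the same on the core of compound 1, since the only clean comparison at this position comes from compound 3 and compound 4, which both carry the chloro-substituted core.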